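The source may report more compounds than this note shows. Statements on the series, on what has been measured and on what is new or still open speak of the compounds shown alone.

Measured so far in an assay on microsomes from liver for inhibition of acyl-CoA desaturase 1 (Rattus norvegicus); a higher number here means a weaker inhibitor, a lower number a stronger inhibitor:

Compound 1, `O=C(NCCC1CC1)c1ccc(N2CCC(Oc3ccccc3C(F)(F)F)CC2)nn1`, gives 14 nM.
Compound 2, `FC(F)(F)c1ccccc1OC1CCN(c2ccc(-n3ccnc3)nn2)CC1`, gives 4 nM.
Compound 3, `CC(C)Cc1nnc(-c2ccc(N3CCC(Oc4ccccc4C(F)(F)F)CC3)nn2)s1`, gives 37 nM.

All three share one core and differ only in the group carried on one aromatic carbon of it. Compound 3 stands highest of the three numbers in this assay, the weakest inhibitor here: a 2.6-fold higher number from compound 1 to compound 3 (0.42 log units; beyond the scatter) and a 9.3-fold higher number from compound 2 to compound 3 (0.97 log units; beyond the scatter). Between the other two, a 3.5-fold lower number from compound 1 to compound 2 (0.54 log units; beyond the scatter).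

Compound 4, `FC(F)(F)c1ccccc1OC1CCN(c2ccc(-c3nnco3)nn2)CC1`, has not yet been measured in this assay. It differs from compound 3 in one place: 1,3,4-oxadiazol-2-yl in place of 5-isobutyl-1,3,4-thiadiazol-2-yl on an aromatic carbon. The group that leaves is the largest of the four groups compared here; the group that enters is small and flat, closest in size to the 1H-imidazol-1-yl of compound 2.

Going by the values given here, two measured steps bear on this change. Both of them show the 5-isobutyl-1,3,4-thiadiazol-2-yl giving a higher number than a smaller group in the same place, by modest amounts, and the smallest group of all, in compound 2, gave the lowest number. On that basis a modest move downward in this assay is expected for compound 4, a 3.1-fold lower number from compound 3 to compound 4 (0.49 log units; beyond the scatter). Compound 4 is therefore estimated at 12 nM, with a range from 4 nM to 40 nM.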

Compound 4, half-maximal inhibitory concentration: 22 nM
Beside the measured number, compound 4's estimate is 1.8-fold (0.26 log units) below it; low and high end bracket the measured number.
By their numbers in this assay, from the lowest: compound 2; then compounds 1, 4 and 3 (each within the scatter of the next, the first and the last beyond it).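

Swapping the 5-isobutyl-1,3,4-thiadiazol-2-yl for the 1,3,4-oxadiazol-2-yl, which has fewer heavy atoms, gives a 1.7-fold lower number from compound 3 to compound 4 (0.23 log units; within the scatter) in this assay, so this change does not separate the two groups, and compound 4 goes against the earlier impression that a smaller group here gives a lower number. Compound 2 remains apart, with a 5.5-fold higher number from compound 2 to compound 4 (0.74 log units; beyond the scatter), which shows that two five-membered aromatic rings at this place can differ beyond the scatter, while a 1.6-fold higher number from compound 1 to compound 4 (0.20 log units; within the scatter) leaves the 1,3,4-oxadiazol-2-yl and the open (2-cyclopropylethyl)carbamoyl group unseparated. No available evidence accounts for what sets the 1H-imidazol-1-yl apart from the 1,3,4-oxadiazol-2-yl.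

On these data alone, this change alters both the ring and the isobutyl chain, so the contribution of each stays open; a 1,3,4-thiadiazol-2-yl without the chain, or a 5-isobutyl-1,3,4-oxadiazol-2-yl, would pull them apart. Also open, as far as these compounds go, is how a group of a different kind at this place, such as a carboxylic acid or a primary amine, would read in this assay.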